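Bromo to methoxy on a weakly active series

The compounds below may be only part of what the source reports. "The series", "measured", "known", "first", "only" and "open" are said of these compounds alone.

- compound 1 `O=C1/C(=C/c2cccc(Br)c2)Cc2ccccc21`: 173000 nM
- compound 2 `O=C1/C(=C/c2ccc(Br)cc2)Cc2ccccc21`: > 500000 nM (a limit, not a number)

Going by the values given here, in a functional assay on MOLT-4 cells (Homo sapiens) for inhibition (on this read-out lower numbers stand for stronger inhibition and higher numbers for weaker inhibition), compound 1 gives 173000 nM, the only true number available and a reading of weak inhibition. Compound 2 is recorded only as a limit of > 500000 nM. Compound 1 therefore stands alone as the single numerical anchor for the series.

Compound 3 `COc1cccc(/C=C2\Cc3ccccc3C2=O)c1` keeps the core of compound 1 and changes one group: methoxy in place of bromo on an aromatic carbon, meta to a large group (methoxy in place of bromo on an aromatic carbon). Among the compounds with values here, no measured step covers this exchange, so the data give no direct size for it. In this assay the expectation is therefore no step beyond the usual scatter, with neither direction favoured, and the reference point remains compound 1 at 173000 nM. The expected change is a 1.2-fold higher number from compound 1 to compound 3 (0.06 log units; within the scatter). Compound 3 is expected at 200000 nM, with an estimated range from 80000 nM to 500000 nM.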

Compound 3, half-maximal inhibitory concentration: > 500000 nM
Compound 3: no number, only a limit (the forecaster's own chance of this, stated with the estimate: 25%); at least 2.5-fold (0.39 log units) between middle value and limit.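

Methoxy in place of bromo on an aromatic carbon, meta to a large group, gives an at least 2.8-fold higher number from compound 1 to compound 3 (0.46 log units; beyond the scatter) in this assay; this exchange now has a measured direction, and the step is a lower bound rather than a size. Bromo at this position, in compound 1 at 173000 nM, therefore remains the only substituent in the compounds shown that gives a true number, and that number already reflects weak inhibition. Compound 3 is recorded only as a limit, and the full size of the step cannot be read because the reading stops at that limit: the limit of > 500000 nM in this assay, at which 2 of the 3 values shown sit.

As far as these compounds go, whether chloro, an amine or a carboxylic acid at this position would give a true number, and whether any of these would improve on compound 1, remains open. With only bromo and methoxy compared here, the data do not say which feature of the exchange accounts for the step, and no property of either group has been measured in the compounds shown.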